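This account rests on a few compounds, and the source may have more. Where it says the series, first, only, none or still open, it means among the compounds named here.

Measured so far in a functional assay on HeLa cells (Homo sapiens) for antiproliferative activity, read by MTT assay; a lower number here means a stronger inhibitor, a higher number a weaker inhibitor:
compound 1, `CCOC(=O)/C=N/c1cnc(Nc2ccc(S(N)(=O)=O)cc2)nc1NC1CCCC1`: 20700 nM
compound 2, `CCOC(=O)/C=N/c1cnc(Nc2ccc(S(N)(=O)=O)cc2)nc1NC(C)C`: 83300 nM
compound 3, `CC(C)Nc1nc(Nc2ccc(S(N)(=O)=O)cc2)ncc1/N=C/c1cccs1`: > 100000 nM (a limit of the assay, not a number)

Compound 2 has the highest of the two numbers in this assay. Among the measured compounds shown here, the nearest is compound 1, and the only step onto compound 2 is a 4.0-fold higher number from compound 1 to compound 2 (0.60 log units; beyond the scatter). For compound 3 the assay reports only a limit, (the limit of > 100000 nM in this assay, at which 1 of the 3 values shown sits). The step of an at least 1.2-fold higher number from compound 2 to compound 3 (0.07 log units; that floor lies within the scatter) therefore has a floor that lies within the scatter and says little about direction.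

Compound 4, `CCOC(=O)/C=N/c1cnc(Nc2ccc(S(N)(=O)=O)cc2)nc1NC1CC1`, differs from compound 2 in one place: cyclopropyl in place of isopropyl on a nitrogen on an aromatic ring. The measured step that bears on this position is a 4.0-fold higher number from compound 1 to compound 2 (0.60 log units; beyond the scatter): the smaller, open isopropyl in place of the cyclopentyl ring raised the number by a modest amount. Cyclopropyl is a ring again, but a far smaller one than cyclopentyl, so the cyclopentyl result cannot simply be carried over. The expectation is a step of a 1.1-fold higher number from compound 2 to compound 4 (0.03 log units; within the scatter) that does not clearly exceed the scatter, if anything toward a somewhat higher number, with a real chance that this assay reports only its limit for compound 4. Compound 4 is estimated at 90000 nM, within a range of 30000 nM to 250000 nM.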

Compound 4, half-maximal inhibitory concentration: > 100000 nM
Compound 4: a limit, no number (the forecaster's own chance of this, stated with the estimate: 40%); middle value at least 1.1-fold (0.04 log units) away from the limit.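

In this assay compound 4 gives > 100000 nM, which is a limit of the assay and not a number. The series now has a ring-for-ring comparison at this nitrogen, an at least 4.8-fold higher number from compound 1 to compound 4 (0.68 log units; beyond the scatter), so the presence of a ring alone does not preserve the number of compound 1, and the cyclopentyl and cyclopropyl rings are clearly not interchangeable here. The step of an at least 1.2-fold higher number from compound 2 to compound 4 (0.07 log units; that floor lies within the scatter) gives no direction, so isopropyl and cyclopropyl cannot be ordered, and the comparison is capped at the top of the measurable range: the limit of > 100000 nM in this assay, at which 2 of the 4 values shown sit.

Open, going by these compounds, is whether cyclohexylamino, or a longer chain such as n-butylamino, on this nitrogen would move the number away from that of compound 1, 20700 nM, in either direction. Also open, on these data alone, is how cyclopentylamino behaves with thiophen-2-yl in place of ethoxycarbonyl on the carbon with a double bond to nitrogen.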